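Swapping the anilino ring substituent in a sulfonamide-tailed quinazoline

The source may hold more compounds than are shown below. What is called first, only, known or untested is meant among the compounds shown, and "the series" means these compounds.

Measured compounds:
compound 1 `COc1cc2ncnc(Nc3cccc(Cl)c3)c2cc1OCCCCC(=O)Nc1ccc(S(N)(=O)=O)cc1`, 30400 nM
compound 2 `COc1cc2ncnc(Nc3ccc(Cl)cc3)c2cc1OCCCCC(=O)Nc1ccc(S(N)(=O)=O)cc1`, 7120 nM

For the measured compounds named here, in a functional assay on A-431 cells (Homo sapiens) for antiproliferative activity, read by MTT assay, with a stated time of 72 h (on this read-out higher numbers stand for weaker inhibition and lower numbers for stronger inhibition), compound 2 holds the lowest of the two numbers, and the step of a 4.3-fold lower number from compound 1 to compound 2 (0.63 log units; beyond the scatter) is the only measured step. Compound 3 `COc1ccccc1Nc1ncnc2cc(OC)c(OCCCCC(=O)Nc3ccc(S(N)(=O)=O)cc3)cc12` differs from compound 2 by 2-methoxyphenyl in place of 4-chlorophenyl on a nitrogen on an aromatic ring. Going by the values given here, no measured step covers this exchange; the single step shows only that moving the chlorine on the anilino ring shifted the number substantially. With that uncertainty, compound 3 is expected to give 20000 nM (range 5000 nM to 80000 nM), a step of a 2.8-fold higher number from compound 2 to compound 3 (0.45 log units; beyond the scatter) expected toward a weaker result.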

Compound 3, half-maximal inhibitory concentration: 24200 nM
Estimate against measurement, compound 3: 1.2-fold (0.08 log units) below; low and high end bracket the measured number.
By their numbers in this assay, from the lowest: compound 2; then compounds 3 and 1 (each within the scatter of the next).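

Putting 2-methoxyphenyl in place of 4-chlorophenyl on the nitrogen gives a 3.4-fold higher number from compound 2 to compound 3 (0.53 log units; beyond the scatter), while putting it in place of 3-chlorophenyl gives a 1.3-fold lower number from compound 1 to compound 3 (0.10 log units; within the scatter), so compound 1 and compound 3 cannot be told apart. Of these three groups, only the 4-chlorophenyl of compound 2 stands apart from the other two. Nothing available explains this difference. The compounds shown leave open how 2-chlorophenyl, 4-methoxyphenyl or plain phenyl would compare, so the effects of the substituent and its place on the ring remain unseparated.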